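Amine substitution on the core of compound 1

The source may hold more compounds than are shown below. What is called first, only, known or untested is meant among the compounds shown, and "the series" means these compounds.

Two compounds have numbers in a functional assay on 3T3-L1 cells (Mus musculus) for inhibition, with a stated time of 20 min, tested at 20 uM; a higher number here means more inhibition at the concentration tested (going by the name of the read-out), a lower number less inhibition. Compound 1 `Cc1ccc(S(=O)(=O)n2cc(CN(Cc3cccc(F)c3F)C(=O)C(F)(F)F)c3ccccc32)cc1` gives -5.5% in this assay, the higher of the two values. Compound 2 `O=C(N(Cc1ccc(F)cc1)Cc1cccc(F)c1F)C(F)(F)F` gives -39.8% in this assay, a number beyond the scatter below that of compound 1; these two structures differ in more than one place, so the gap is simply what the two values show. Both numbers sit at or below zero inhibition, so neither compound shows appreciable inhibition at the concentration tested.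

Compound 3 `Cc1ccc(S(=O)(=O)n2cc(CN(Cc3ccccc3)Cc3cccc(F)c3F)c3ccccc32)cc1` is not yet measured. It differs from compound 1 in one place: benzyl in place of (trifluoromethyl)carbonyl on an amine nitrogen. Among the compounds with values here, no pair of measured compounds shows the effect of such a change, so there is nothing to anchor its direction. The expectation is a step from compound 1 of a number 2.5 percentage points higher from compound 1 to compound 3 (within the scatter) in this assay, that is, no change beyond the scatter, because compound 1 itself shows only -5.5% and a shift away from zero in either direction has no support here. Compound 3 is therefore estimated at -3% in this assay, with a range from -28% to 20%.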

Compound 3, a percentage reported as inhibition, at one concentration (the size of the read-out at that concentration, not a potency): -13.1%
Estimate against measurement, compound 3: 10.1 percentage points above; low and high end bracket the measured number.
By their numbers in this assay, from the lowest: compound 2; then compounds 3 and 1 (each within the scatter of the next).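

In this assay, within the data shown here, the one-place swap of (trifluoromethyl)carbonyl for benzyl on this amine nitrogen gives a number 7.6 percentage points lower from compound 1 to compound 3 (within the scatter), the first single-change comparison. At this position, then, a group with one six-membered aromatic ring of carbon only and no hydrogen-bond acceptor can take the place of a ring-free group with one hydrogen-bond acceptor, with no difference beyond the scatter, and compound 3 joins compound 1 in giving a negative number, so this change does not bring appreciable inhibition at the concentration tested. No measured property in hand bears on this result.

Since both members of the pair lie in a range without appreciable inhibition, the step leaves open whether the group on this nitrogen matters at all for the read-out in a compound that does inhibit. Also open, from the compounds shown here alone, is how an acetyl group, a chain ending in a carboxylic acid or a chain ending in an amine would read on the same nitrogen, since the present pair covers only (trifluoromethyl)carbonyl and benzyl on the core of compound 1.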